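Compound 4: trifluoromethyl in place of hydroxyamino

This account rests on a few compounds, and the source may have more. Where it says the series, first, only, none or still open, it means among the compounds named here.

Within the data shown here, in a functional assay on NCI-H661 cells (Homo sapiens) for antiproliferative activity, read by MTT assay, with a stated time of 72 h (a lower number here means a stronger inhibitor, a higher number a weaker inhibitor), three compounds have values so far.

- compound 1 `COc1ccc(-c2noc(CCCCCCC(=O)NO)n2)cc1` gives 20400 nM
- compound 2 `O=C(CCCCCCc1nc(-c2ccc(F)cc2)no1)NO` gives 19400 nM
- compound 3 `O=C(CCCCCCc1nc(-c2cccs2)no1)NO` gives 9460 nM

Compound 2 at 19400 nM stands at the high end of this small set. The gap to its nearest neighbour is a 1.1-fold lower number from compound 1 to compound 2 (0.02 log units; within the scatter), and the only gap beyond the scatter is a 2.1-fold lower number from compound 2 to compound 3 (0.31 log units; beyond the scatter).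

Compound 4 `O=C(CCCCCCc1nc(-c2ccc(F)cc2)no1)C(F)(F)F` has trifluoromethyl in place of hydroxyamino on a carbonyl carbon.

Neither measured step touches that carbonyl carbon. Both are changes on an aromatic carbon, so they only show how little the number has moved so far, with a 2.1-fold lower number from compound 2 to compound 3 (0.31 log units; beyond the scatter) as the larger. Among the measured compounds shown here, no measured compound lacks the hydroxycarbamoyl group, so the size of this step is poorly constrained. A move to a higher number in this assay is expected, with a wide margin. The expected step is a 1.8-fold higher number from compound 2 to compound 4 (0.26 log units; within the scatter), and it could fall within the scatter. For compound 4 the estimated value is 35000 nM, with an expected range of 10000 nM to 100000 nM in this assay.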

Compound 4, half-maximal inhibitory concentration: 12700 nM
Compound 4: the middle estimate sits 2.8-fold (0.44 log units) above what was measured; measured number inside the range.
By their numbers in this assay, from the lowest: compounds 3, 4, 2 and 1 (each within the scatter of the next, the first and the last beyond it).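

Among these compounds, the step of a 1.5-fold lower number from compound 2 to compound 4 (0.18 log units; within the scatter) in this assay is the first at the carbonyl carbon, as compounds 1, 2 and 3 all carry hydroxycarbamoyl there. In this one pair, with the rest of compound 2 kept, (trifluoromethyl)carbonyl stands in place of hydroxycarbamoyl with no difference beyond the scatter, so antiproliferative activity at this level does not depend on hydroxycarbamoyl. No available measurement bears on why the two groups read alike.

From the compounds shown here alone, whether the same replacement reads alike on the thiophen-2-yl side of compound 3 remains open. Also open, going by these compounds, is how a carboxylic acid or a methyl ketone at this carbonyl carbon, or a longer chain carrying (trifluoromethyl)carbonyl, would read in this assay for these cells.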